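The compounds below may be only part of what the source reports. "The series", "measured", "known", "first", "only" and "open" are said of these compounds alone.

Compound 1 `Cc1ccc(S(=O)(=O)Oc2ccccc2/C=C(\C#N)C(=O)Nc2nnc(C)s2)cc1` is the starting point of this small set; in a functional assay on RS4-11 cells (Homo sapiens) for inhibition, read by CCK-8 assay, with a stated time of 48 h, tested at 20 uM (on this read-out higher numbers stand for more inhibition of growth at the one concentration tested and lower numbers for less inhibition of growth), compound 1 gives 33%. Compound 2 `COc1ccc(Cc2nnc(NC(=O)/C(C#N)=C/c3ccccc3OS(=O)(=O)c3ccc(C)cc3)s2)cc1` gives 70%, and compound 3 `Cc1ccc(S(=O)(=O)Oc2ccccc2/C=C(\C#N)C(=O)Nc2nnc(Cc3ccccc3)s2)cc1` gives 69%. Two large steps shape the set: a number 37 percentage points higher from compound 1 to compound 2 (beyond the scatter) and a number 36 percentage points higher from compound 1 to compound 3 (beyond the scatter). In each of these two steps the group on a saturated chain carbon bound to an aromatic carbon is what differs. Between the two larger compounds, a number 1 percentage points lower from compound 2 to compound 3 (within the scatter). Compound 3 thus stands second highest of the three numbers, with compound 2 nearest to it and compound 1 furthest from it.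

Compound 4 `N#C/C(=C\c1ccccc1OS(=O)(=O)c1ccccc1[N+](=O)[O-])C(=O)Nc1nnc(Cc2ccccc2)s1` has not yet been measured. It differs from compound 3 in a single place: 2-nitrophenyl in place of 4-methylphenyl on a sulfonyl sulfur. Among the measured compounds shown here, none of the measured steps bears on this place; every one of them altered the group on the saturated chain carbon, while the sulfonyl side stayed the same throughout. For the measured compounds named here, there is accordingly no measured step from which a direction could be read. The step of a number 4 percentage points lower from compound 3 to compound 4 (within the scatter) is expected to stay within the scatter, and the range is kept wide to reflect the missing precedent. The estimate for compound 4 in this assay is 65%, expected to lie between 40% and 85%.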

Compound 4, percent growth inhibition at one concentration: 71%
Compound 4: middle estimate off by 6 percentage points, on the low side; the range from low to high includes it.
By their numbers in this assay, from the lowest: compound 1; then compounds 3, 2 and 4 (each within the scatter of the next).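

In this assay the sulfonyl side is shown for the first time to accept a change of aryl group: 2-nitrophenyl in place of 4-methylphenyl on a sulfonyl sulfur gives a number 2 percentage points higher from compound 3 to compound 4 (within the scatter) and so leaves the two compounds indistinguishable. The earlier steps shown here, such as a number 36 percentage points higher from compound 1 to compound 3 (beyond the scatter), concerned only the group on the saturated chain carbon, so they could not show whether the sulfonyl side matters in the same way. The entering group carries nitrogen, oxygen and hydrogen-bond acceptors that 4-methylphenyl lacks, yet this difference does not register in the read-out, and no measurement on hand explains that outcome.

From the compounds shown here alone, whether the aryl group on the sulfonyl sulfur could give way to a plain methyl group, or to a phenyl ring carrying an amine or a carboxylic acid, remains open, as does whether 2-nitrophenyl would behave alike with the smaller methyl group of compound 1 on the other side of the molecule. Going by these compounds, with a single tested concentration, it also remains open whether compound 2, compound 3 and compound 4 would separate at other concentrations.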